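Ring nitrogen substituent and zebrafish activity in the series

The compounds below may be only part of what the source reports. "The series", "measured", "known", "first", "only" and "open" are said of these compounds alone.

The compounds are compared in a functional assay (strain AB) with Danio rerio as the target, read by microscopy, with a stated time of 1 h; a higher number here means that more compound is needed for the effect, a lower number that less compound is needed. Compound 1 `CC(C)(C)OC(=O)CCCC[N+]1(C)CCc2c(sc(NC(=O)Nc3ccc(Cl)cc3)c2C(N)=O)C1` gives 140 nM in this assay. Compound 3 `CCN1CCc2c(sc(NC(=O)Nc3cccc(C)c3)c2C(N)=O)C1` gives 13000 nM in this assay. Compound 2 `CC(C)(C)OC(=O)N1CCc2c(sc(NC(=O)Nc3ccc(Cl)cc3)c2C(N)=O)C1` is reported in this assay only as a limit, > 25000 nM, with no number behind it. That puts compound 2 at the upper boundary of the values shown: the relevant observation is the limit of > 25000 nM in this assay, at which 1 of the 3 values shown sits, and its value stands apart from the numbers of compound 1 and compound 3, which both lie below that boundary.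

Compound 4 `CCCN1CCc2c(sc(NC(=O)Nc3ccc(Cl)cc3)c2C(N)=O)C1` has not been measured in this assay. The change from compound 2 to compound 4 is propyl in place of tert-butoxycarbonyl on an amine nitrogen in a ring. Among the compounds with values here, no pair of measured compounds differs in a single place, so no measured step gives the size of this change directly. The expectation is nonetheless a step beyond the usual scatter, toward less compound needed, since compound 2 sits at the limit and the two substituted amines compound 1 and compound 3 both return numbers. Compound 4 is estimated at 5000 nM in this assay, with a range from 1000 nM to 25000 nM. The expected step is an at least 5.0-fold lower number from compound 2 to compound 4 (0.69 log units; beyond the scatter).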

Compound 4, half-maximal effective concentration: 3500 nM
Compound 4: the middle estimate sits 1.4-fold (0.15 log units) above what was measured; measured number inside the range.
By their numbers in this assay, from the lowest: compound 1; then compound 4; then compound 3. At a limit, above all of these: compound 2.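

In this assay, the amine nitrogen in the ring is now a position where one change, with the rest of the molecule held constant, has a measured effect: propyl in place of tert-butoxycarbonyl gives an at least 7.1-fold lower number from compound 2 to compound 4 (0.85 log units; beyond the scatter). The step fixes only a minimum size, with compound 2 held as a limit and not a number: the limit of > 25000 nM in this assay, at which 1 of the 4 values shown sits. The change removes a group with 2 hydrogen-bond acceptors and a double bond outside aromatic rings, and enters a smaller group with 0 hydrogen-bond acceptors.

This single step swaps all of these features together, so the data cannot assign the effect to any one of them. Also open, as far as these compounds go, is how an acetyl group, a benzyl group or a longer chain on this nitrogen would read in this assay.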